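Halogen swap on the biaryl of a Raji cytotoxicity series

The source may hold more compounds than are shown below. What is called first, only, known or untested is meant among the compounds shown, and "the series" means these compounds.

Compound 2 (`CCOC(=O)CCCCCOc1cccc(CN(C(=O)c2ccc(-c3cccc(Br)c3)cc2)C(C)C)c1`) is the measured parent of the step. In an ADME assay on Raji cells (Homo sapiens) for cytotoxicity, read by CellTiter-Glo and resazurin assay, with a stated time of 72 h (on this read-out higher numbers stand for an effect only at larger amounts of compound and lower numbers for an effect already at smaller amounts), compound 2 gives only a limit, > 26000 nM. Compound 1 (`CCOC(=O)CCCCCOc1cccc(CN(C(=O)c2ccc(-c3ccc4[nH]ccc4c3)cc2)C(C)C)c1`) carries an indolyl in place of the halophenyl. In this assay compound 1 also gives only a limit, > 26000 nM. The step that the two limits leave unreadable from compound 1 to compound 2 cannot be sized because the limit of > 26000 nM in this assay, at which 2 of the 2 values shown sit, holds both values. Compound 2 thus stands at the ceiling of the numbers shown, with no readable difference to any other compound.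

Compound 3 (`CCOC(=O)CCCCCOc1cccc(CN(C(=O)c2ccc(-c3cccc(Cl)c3)cc2)C(C)C)c1`) differs from compound 2 by the change (chloro in place of bromo on an aromatic carbon), chloro in place of bromo on an aromatic carbon. Among the compounds with values here, no measured step bears on this change: the only step is unreadable, and it concerns a different position. For compound 3 the expectation is therefore a step within the scatter, a step that the limit leaves unreadable from compound 2 to compound 3, and most likely another limit in this assay. Compound 3 is estimated at 30000 nM, with a range from 15000 nM to 60000 nM.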

Compound 3, half-maximal effective concentration: > 18400 nM
Compound 3: only a limit was reported; the forecaster's own chance of this, stated with the estimate: 80%; the middle value lies beyond the limit too.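

Compound 3 gives only a limit in this assay, > 18400 nM. Within the data shown here, compound 1, compound 2 and compound 3 all stand as limits, and no step between them can be read. Left open is whether chloro, bromo or the indolyl group makes any difference to the half-maximal effective concentration, and where that concentration lies for any of the three compounds.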